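The compounds below may be only part of what the source reports. "The series", "measured", "known", "first", "only" and "open" are said of these compounds alone.

Within the data shown here, compound 2, with the structure `O=C(CN1CCC(c2cccc[n+]2[O-])CC1)Nc1cccc(Cl)c1`, stands at the top of the two numbers measured so far: in a functional assay on HEK293 cells for agonist activity at D(4) dopamine receptor (Homo sapiens), read by FLIPR (on this read-out lower numbers stand for smaller maximal responses and higher numbers for larger maximal responses), compound 2 reaches 76%. Compound 1, with the structure `CCc1cccc(NC(=O)CN2CCC(c3cccc[n+]3[O-])CC2)c1`, reaches 62% in this assay. Among the measured compounds shown here, the one measured step between them is a number 14 percentage points higher from compound 1 to compound 2 (beyond the scatter), which is the exchange of one group for another on an aromatic carbon.

Compound 3, with the structure `O=C(CN1CCC(c2cccc[n+]2[O-])CC1)Nc1cccc(C(F)(F)F)c1`, is the next member of this series. Compared with compound 2 the change is trifluoromethyl in place of chloro on an aromatic carbon.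

For the measured compounds named here, only the step from compound 1 to compound 2 bears on this question, and it concerns a different pair of groups on the same aromatic carbon; it was modest in size. Going by the values given here, no measured step involves trifluoromethyl, so the direction of the new step cannot be read from the data. The expected outcome for compound 3 is therefore a step of a number 2 percentage points lower from compound 2 to compound 3 (within the scatter), within the scatter, and the estimated value for compound 3 in this assay is 74% with a range from 58% to 90%.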

Compound 3, largest response reached (reported as efficacy), in percent of the reference or control that the assay uses: 75%
Estimate against measurement, compound 3: 1 percentage points below; the range from low to high includes it.
By their numbers in this assay, from the lowest: compound 1; then compounds 3 and 2 (each within the scatter of the next).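

The exchange of chloro for trifluoromethyl on this aromatic carbon enlarges the group from 1 heavy atom to 4, yet in this assay the maximal response holds level (a number 1 percentage points lower from compound 2 to compound 3 (within the scatter)), so at this position the read-out tolerates that exchange without a change that can be told from the scatter. The comparison with ethyl on the same carbon (a number 13 percentage points higher from compound 1 to compound 3 (beyond the scatter)) repeats what the chloro compound showed, which means that among these three compounds, two groups sit together and compound 1, with ethyl, is the one that stands apart. No measurement at hand accounts for why ethyl differs from the other two groups or why chloro and trifluoromethyl match.

On these data alone, whether a methoxy group, a nitrile or an amine on this carbon would stay level with chloro and trifluoromethyl or fall toward ethyl remains open. Also open, as far as these compounds go, is whether the same picture would hold for these groups on another carbon of the ring, since all three compounds carry their group in the same place.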